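The compounds below may be only part of what the source reports. "The series", "measured", "known", "first", "only" and "open" are said of these compounds alone.

Compound 1 `CC(C)Nc1nc(N)nc2c1ncn2/C=C1/CC1(CO)CO`: in an ADME assay on BCBL1 cells (Homo sapiens) for cytotoxicity, with a stated time of 7 days (on this read-out higher numbers stand for lower toxicity in this test and lower numbers for higher toxicity in this test), compound 1 reports only a limit, > 20000 nM.
Compound 2 `Nc1nc2c(ncn2/C=C2/CC2(CO)CO)c(=O)[nH]1`: in this assay compound 2 likewise reports a limit, > 20000 nM.
Compound 3 `CCCCCCCCSc1nc(N)nc2c1ncn2/C=C1/CC1(CO)CO`: in this assay compound 3 also reports a limit, > 20000 nM.

Compound 1 therefore stands at the assay limit, where all three measured compounds sit (the limit of > 20000 nM in this assay, at which 3 of the 3 values shown sit). Going by the values given here, the one measured step that touches compound 1, a step that the two limits leave unreadable from compound 1 to compound 3, is left unreadable by those limits, so it sets no size for the step to compound 4 `Nc1nc(SC2CCCC2)c2ncn(/C=C3/CC3(CO)CO)c2n1`. That step changes one group: cyclopentylsulfanyl in place of isopropylamino on an aromatic carbon. With every shown value a limit, no step beyond the scatter is expected in this assay. Compound 4 is expected near 30000 nM, within 10000 nM to 100000 nM, corresponding to an expected step that the limit leaves unreadable from compound 1 to compound 4.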

Compound 4, half-maximal cytotoxic concentration: > 20000 nM
Compound 4: only a limit was reported (the forecaster's own chance of this, stated with the estimate: 85%); the middle value lies beyond the limit too.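

Compound 4 reports only a limit, so its steps from compound 1 and from compound 3 cannot be read: the limit of > 20000 nM in this assay, at which 4 of the 4 values shown sit. The compounds shown leave open how far any of these groups on the aromatic carbon changes toxicity in this assay.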